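Hydroxamate carrier swap on the carboxy-bearing pyrrolidine series

The source may report more compounds than this note shows. Statements on the series, on what has been measured and on what is new or still open speak of the compounds shown alone.

Compound 3 `O=C(NO)c1cccc(-c2cn([C@H]3C[C@@H](C(=O)O)N(Cc4ccccc4)C3)nn2)c1` carries a carboxy group on a saturated ring carbon and a 3-(hydroxycarbamoyl)phenyl group on the shared core. In an assay on Sf9 cells for inhibition of histone deacetylase 11 (Homo sapiens), read by fluorescence, tested at 0.5 uM (on this read-out higher numbers stand for more inhibition at the one concentration tested (going by the name of the read-out) and lower numbers for less inhibition), compound 3 gives 14%, which is the lowest of the two numbers in hand; the nearest number belongs to compound 2 `O=C(/C=C/c1cn([C@H]2C[C@@H](CO)N(Cc3ccccc3)C2)nn1)NO`, which gives 35% in this assay, a gap beyond the usual scatter. Compound 1 `O=C(NO)c1cccc(-c2cn([C@H]3C[C@@H](CO)N(Cc4ccccc4)C3)nn2)c1` is the hydroxymethyl counterpart of compound 3. In this assay compound 1 reaches only the limit, < 10%, a limit and not a number (the limit of < 10% in this assay, at which 1 of the 3 values shown sits).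

Going by the values given here, the one measured step that touches the scaffold, a number at least 4 percentage points higher from compound 1 to compound 3 (that floor lies within the scatter), stays within the scatter, so the carboxy group itself has not shifted the read-out in any clear way.

Compound 4 `O=C(/C=C/c1cn([C@H]2C[C@@H](C(=O)O)N(Cc3ccccc3)C2)nn1)NO` differs from compound 3 as follows: 2-(hydroxycarbamoyl)ethenyl in place of 3-(hydroxycarbamoyl)phenyl on an aromatic carbon. Compounds 1 and 2 share this same exchange of the hydroxamate carrier on the hydroxymethyl scaffold, and their two values move from a limit to a clear number, which points to a sizeable rise. For compound 4 a step of a number 24 percentage points higher from compound 3 to compound 4 (beyond the scatter) is therefore expected, and compound 4 is estimated at 38%, ranging from 20% to 56%.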

Compound 4, a percentage reported as inhibition, at one concentration (the size of the read-out at that concentration, not a potency): 23%
Compound 4: middle estimate off by 15 percentage points, on the high side; measured number inside the range.
By their numbers in this assay, from the lowest: compounds 3 and 4 (each within the scatter of the next); then compound 2. At a limit, below all of these: compound 1.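

In this assay, exchanging 3-(hydroxycarbamoyl)phenyl for 2-(hydroxycarbamoyl)ethenyl on the carboxy-bearing scaffold gives a number 9 percentage points higher from compound 3 to compound 4 (within the scatter), so on this scaffold, unlike the hydroxymethyl pair, the two hydroxamate carriers are not clearly separated at this position. Going by these compounds alone, the second new step gives the first reading of carboxy in place of hydroxymethyl on the saturated ring carbon that clears the scatter, a number 12 percentage points lower from compound 2 to compound 4 (beyond the scatter), and it is a modest loss seen with the 2-(hydroxycarbamoyl)ethenyl carrier. In these two pairs, the outcome of the carboxy exchange differs with the carrier on the aromatic carbon: the same change on two cores in this assay, a number at least 4 percentage points higher (that floor lies within the scatter) from compound 1 to compound 3 and a number 12 percentage points lower (beyond the scatter) from compound 2 to compound 4, at least 16 percentage points apart, beyond the scatter of two such steps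

From the compounds shown here alone, compound 1 stands at < 10%, which is a limit and not a number, so the full size of the step on the 3-(hydroxycarbamoyl)phenyl core stays unknown. Going by these compounds, it also remains open whether a primary amide or an amine on the saturated ring carbon would track the hydroxymethyl or the carboxy values with either carrier, and whether a longer chain carrying the hydroxamate would separate the two scaffolds further.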